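A few compounds are considered here, and "the series" means these few. Any claim that something is new, unique, unknown or untested is made for them only; others in the source may bear on it.

Measured so far in a functional assay on U-373MG ATCC cells (Homo sapiens) for inhibition, read by MTT assay, with a stated time of 72 h; a lower number here means a stronger inhibitor, a higher number a weaker inhibitor:

- Compound 1 `CC1(C)CC(NC(=S)Nc2ccc(C#N)cc2)c2cc(Cl)ccc2O1`: 10000 nM
- Compound 2 `CC(C)NC(=S)NC1CC(C)(C)Oc2ccc(Cl)cc21`: 57000 nM

Of these two compounds, compound 2 has the higher number at 57000 nM, which makes it the weaker inhibitor. The next compound to be tested is compound 3 `CCNC(=S)NC1CC(C)(C)Oc2ccc(Cl)cc21`. It keeps the shared core and changes isopropyl to ethyl, with hydrogen in place of methyl on a saturated chain carbon bound to an amide-type nitrogen and a saturated chain carbon.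

Going by the values given here, only one measured step bears on this change: a 5.7-fold higher number from compound 1 to compound 2 (0.76 log units; beyond the scatter). That step, a modest one, put isopropyl in place of 4-cyanophenyl on an amide-type nitrogen. Among the compounds with values here, it exchanged a far larger group than the methyl at stake here, and no measured step shows what removing a methyl does on its own. In this assay, a step beyond the usual scatter is therefore not expected, and no direction can be favoured. The expected result is a 1.1-fold higher number from compound 2 to compound 3 (0.02 log units; within the scatter). Compound 3 is estimated at 60000 nM, with an expected range from 25000 nM to 130000 nM.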

Compound 3, half-maximal inhibitory concentration: 96000 nM
Compound 3: the middle estimate sits 1.6-fold (0.20 log units) below what was measured, and the stated range covers the measured number.
By their numbers in this assay, from the lowest: compound 1; then compounds 2 and 3 (each within the scatter of the next).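

In this assay, going by these compounds alone, this is the first step that isolates a single methyl: hydrogen in place of methyl on a saturated chain carbon, turning isopropyl into ethyl, gives a 1.7-fold higher number from compound 2 to compound 3 (0.23 log units; within the scatter) and so leaves compound 2 and compound 3 indistinguishable in this assay. Isopropyl and ethyl therefore read alike on this amide-type nitrogen, while ethyl in place of 4-cyanophenyl gives a 9.6-fold higher number from compound 1 to compound 3 (0.98 log units; beyond the scatter) and repeats, with a second small chain, the separation from compound 1 first seen in a 5.7-fold higher number from compound 1 to compound 2 (0.76 log units; beyond the scatter). No measurement among these compounds gives a reason for either step, so the numbers describe what happens without explaining it.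

Still open, as far as these compounds go, is whether a methyl or a longer chain such as n-butyl on this nitrogen would read like ethyl and isopropyl or would move toward compound 1 at 10000 nM. It is also unknown whether a plain phenyl without the nitrile, or a phenyl carrying a carboxylic acid instead, would keep the number of compound 1.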